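The source may hold more compounds than are shown below. What is called first, only, known or untested is meant among the compounds shown, and "the series" means these compounds.

Of the compounds shown here, three from this series have been measured in a physicochemical assay for lipophilicity, read by HPLC, in phosphate buffer, measured as chromatographic lipophilicity, at pH 7.4; on this read-out lower numbers stand for lower lipophilicity and higher numbers for higher lipophilicity. Compound 1, with the structure `CCOc1ccc2nc(C(F)(F)F)cc(OCC(=O)Nc3cc(C)cc(C)c3)c2c1`, gives 7.55. Compound 2, with the structure `COc1ccc2nc(C)c(NC(=O)C(=O)Nc3cc(C)cc(C)c3)c(O)c2c1`, gives 3.76. Compound 3, with the structure `COc1ccc2nc(C)cc(OCC(=O)Nc3cccc(C)c3)c2c1`, gives 4.83. On these numbers compound 3 stands second highest of the three: its nearest neighbour is compound 2, which lies lower by a gap beyond the usual scatter, and the furthest is compound 1, which lies higher by a still wider gap, also beyond the scatter. No two of the measured compounds differ in only one place, so none of these gaps can be tied to a single structural change.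

Compound 4, with the structure `COc1ccc2nc(C)cc(OCC(=O)Nc3ccncc3)c2c1`, has not yet been measured. It differs from compound 3 in one place: pyridin-4-yl in place of 3-methylphenyl on an amide-type nitrogen. A six-membered aromatic ring of carbon only leaves, and a six-membered aromatic ring with one hetero atom and one hydrogen-bond acceptor enters on the amide-type nitrogen.

For this change a downward step in this assay is expected, well beyond the scatter, and the estimated step of a number 1.53 log units lower from compound 3 to compound 4 (beyond the scatter) reflects that. Compound 4 is accordingly expected to give about 3.3, within a range from 2.6 to 4.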

Compound 4, distribution coefficient: 2.5
The estimate for compound 4 lay 0.80 log units above the measured number, and the stated range ends above it.
By their numbers in this assay, from the lowest: compound 4; then compound 2; then compound 3; then compound 1.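

In this assay, putting pyridin-4-yl in place of 3-methylphenyl on the amide-type nitrogen gives a number 2.33 log units lower from compound 3 to compound 4 (beyond the scatter). Within the data shown here, this is the first gap that can be tied to a single structural change, and it shows that the read-out responds strongly to what sits at this position, even though the core and the linking chain stay the same. The change swaps a ring of carbon only, with no hydrogen-bond acceptor, for a ring with one nitrogen and one hydrogen-bond acceptor, but no measurement at hand explains the size of the step.

The compounds shown leave open how much of the step belongs to the methyl group that leaves and how much to the ring nitrogen that enters, as the two come together in this one change. A plain phenyl on the same amide-type nitrogen would separate those two parts, and a pyridin-3-yl ring would show whether the place of the nitrogen within the ring also counts.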